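The compounds below may be only part of what the source reports. "The series", "measured", "known", "first", "only" and "open" are said of these compounds alone.

Series notes. Compound 2 `CCC1(Cc2ccccc2)OS(=O)(=O)C=C1OCc1ccccc1` gives the highest number of the three in an ADME assay on HEL cells (Homo sapiens) for cytotoxicity, with a stated time of 3 days (on this read-out lower numbers stand for higher toxicity in this test and higher numbers for lower toxicity in this test), at 200000 nM; compound 3 `CC1(Cc2ccccc2)OS(=O)(=O)C=C1OCc1ccccc1` gives 68000 nM and compound 1 `CCC1(Cc2ccccc2)OS(=O)(=O)C=C1OCc1ccc(Cl)c(Cl)c1` gives 36700 nM. Compound 4 `CCC1(Cc2ccccc2)OS(=O)(=O)C=C1OC(=O)c1ccccc1` differs from compound 2 in one place: benzoyl in place of benzyl on an oxygen on an unsaturated carbon. Among the measured compounds shown here, no measured step exchanges benzyl for benzoyl, so the two recorded steps bear only indirectly: a 5.4-fold higher number from compound 1 to compound 2 (0.74 log units; beyond the scatter) and a 2.9-fold lower number from compound 2 to compound 3 (0.47 log units; beyond the scatter), each modest and each beyond the scatter. On that basis a modest downward step in this assay is expected, a 1.7-fold lower number from compound 2 to compound 4 (0.22 log units; within the scatter), though a result within the scatter of compound 2 would not surprise. The estimate for compound 4 in this assay is 120000 nM, with a range from 40000 nM to 350000 nM.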

Compound 4, half-maximal cytotoxic concentration: > 200000 nM
Compound 4: no number, only a limit; the forecaster's own chance of this, stated with the estimate: 20%; middle value at least 1.6-fold (0.22 log units) away from the limit.
By their numbers in this assay, from the lowest: compounds 1 and 3 (each within the scatter of the next); then compound 2.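

In this assay compound 4 gives a limit and not a number: the limit of > 200000 nM in this assay, at which 1 of the 4 values shown sits. Benzoyl in place of benzyl on an oxygen on an unsaturated carbon gives a number no lower from compound 2 to compound 4 (the limit leaves the size open), the first sign that a carbonyl at this place does not lower the number in this test. The earlier exchange at this place, involving 3,4-dichlorophenyl, showed only a change in the aromatic group, not in the link to the oxygen.

As far as these compounds go, how an amine or a carboxylic acid on the benzoyl group would read stays open. So does a longer chain in place of benzoyl.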